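Adding a hydroxy to the side chain of compound 2

This account rests on a few compounds, and the source may have more. Where it says the series, first, only, none or still open, it means among the compounds named here.

The set holds three measured compounds and one still to be tested, all in a functional assay on KB cells (Homo sapiens) for cytotoxicity; a higher number here means that more compound is needed for the effect, a lower number that less compound is needed. Compound 1, `CCC[C@@H](OC(C)=O)C1=C(Br)[C@@](CI)(OC)OC1=O`, gives 4.1 ug/mL in this assay. Compound 2, `CCCCC1=C(Br)/C(=C/Br)OC1=O`, returns only a limit of the assay in this assay, namely > 20 ug/mL. Compound 3, `CCCCC1=C(Br)C(=C(Br)Br)OC1=O`, likewise returns only a limit in this assay, > 20 ug/mL. Compound 2 therefore stands at the limit of > 20 ug/mL in this assay, at which 2 of the 3 values shown sit, sharing that place with compound 3, while compound 1 alone carries a number.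

The unmeasured compound 4, `CCC[C@@H](O)C1=C(Br)/C(=C/Br)OC1=O`, arises from compound 2 by a single change: hydroxy in place of hydrogen on a saturated chain carbon bound to a double-bonded ring carbon and a saturated chain carbon. Among the measured compounds shown here, no measured pair in the set shows this change, and compound 1 rests on a different core, so it supplies no step to lean on. Since compound 2 sits at the limit, a change in this assay can only be seen if compound 4 drops to a measurable value; the author expects at most a modest step in that direction, and quite possibly none beyond the scatter. Compound 4 is estimated at 15 ug/mL, with a range from 5 ug/mL to 40 ug/mL. The expected step is an at least 1.3-fold lower number from compound 2 to compound 4 (0.12 log units; that floor lies within the scatter).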

Compound 4, concentration for half-maximal effect: 3.4 ug/mL
Beside the measured number, compound 4's estimate is 4.4-fold (0.64 log units) above it; measured number outside the range, below it.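

In this assay compound 2 gives > 20 ug/mL, which is a limit of the assay and not a number. Hydroxy in place of hydrogen on a saturated chain carbon bound to a double-bonded ring carbon and a saturated chain carbon provides the first single-change comparison in the set, and the result is an at least 5.8-fold lower number from compound 2 to compound 4 (0.76 log units; beyond the scatter), showing that this position can respond and that this one change is enough to move the compound off the limit to a measurable value. The true size of the step remains unknown, and it can be read only as a floor because compound 2 carries no number: the limit of > 20 ug/mL in this assay, at which 2 of the 4 values shown sit.

The compounds shown leave open whether the hydroxy itself is required at this position or whether a methoxy, an amine or an acetate would serve as well, since compound 1 carries an acetate on its side chain but differs from compound 4 in more than one place. They also leave open whether the opposite arrangement at the hydroxy-bearing carbon would behave alike, and whether the same change would have a similar effect on compound 3.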